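The source may hold more compounds than are shown below. What is called first, only, known or untested is meant among the compounds shown, and "the series" means these compounds.

In a functional assay for inhibition, with Homo sapiens as the target (on this read-out higher numbers stand for weaker binding and lower numbers for tighter binding), compound 1 `Cc1ccc(C#N)c(OC(C)(C)C2OCC(C/C=C\CCC(=O)O)C(c3cccnc3)O2)c1` gives 15.9 nM and compound 2 `CC(C)(Oc1ccccc1[N+](=O)[O-])C1OCC(C/C=C\CCC(=O)O)C(c2cccnc2)O1` gives 11.2 nM, so the two stand within the scatter of each other. Compound 3 `COc1ccc(OC(C)(C)C2OCC(C/C=C\CCC(=O)O)C(c3cccnc3)O2)c([N+](=O)[O-])c1` follows from compound 2 by methoxy in place of hydrogen on an aromatic carbon. Among the compounds with values here, the only measured step, a 1.4-fold lower number from compound 1 to compound 2 (0.15 log units; within the scatter), also changes the aryl group on the oxygen and stays within the scatter. It does not test methoxy directly, so no step beyond the scatter is expected, in either direction. The expected 1.1-fold higher number from compound 2 to compound 3 (0.03 log units; within the scatter) is correspondingly small. Compound 3 is estimated at 12 nM, with an expected range of 5 nM to 30 nM.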

Compound 3, dissociation constant: 6.17 nM
For compound 3 the middle estimate is 1.9-fold (0.29 log units) above the measured one; the range from low to high includes it.
By their numbers in this assay, from the lowest: compounds 3, 2 and 1 (each within the scatter of the next, the first and the last beyond it).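

Methoxy on the aromatic carbon para to a large group and meta to the nitro group gets its first direct test here in this assay, and the step stays within the scatter: a 1.8-fold lower number from compound 2 to compound 3 (0.26 log units; within the scatter). Only a 2.6-fold lower number from compound 1 to compound 3 (0.41 log units; beyond the scatter) passes beyond the scatter, and it exchanges the whole 2-cyano-5-methylphenyl group for 4-methoxy-2-nitrophenyl, so it cannot be assigned to methoxy alone. No supporting evidence bears on this result.

Open, from the compounds shown here alone, is whether ethoxy or an amine at the same place would read differently from methoxy. Also open, going by these compounds, is whether methoxy gives a similar step without the nitro group.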